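The source may hold more compounds than are shown below. What is called first, only, known or untested is meant among the compounds shown, and "the series" means these compounds.

Compound 3 `CCn1c(C(=O)NCCCO)ccc1C(CC)(CC)c1ccc(OCS(=O)(=O)c2ccccc2)c(C)c1` carries a 3-hydroxypropyl group on its amide-type nitrogen and gives 26600 nM in a functional assay on BXPC-3 cells (Homo sapiens) for antiproliferative activity, read by MTT assay, with a stated time of 24 h (a higher number here means a weaker inhibitor, a lower number a stronger inhibitor), the measure followed here. Compound 1 `CCn1c(C(=O)NC2(CO)CC2)ccc1C(CC)(CC)c1ccc(OCS(=O)(=O)c2ccccc2)c(C)c1`, with 1-(hydroxymethyl)cyclopropyl on that nitrogen, gives 45400 nM and sits level with compound 3, since the step of a 1.7-fold lower number from compound 1 to compound 3 (0.23 log units; within the scatter) does not exceed the usual scatter. Compound 2 `CCn1c(C(=O)N[C@H](CO)C(C)C)ccc1C(CC)(CC)c1ccc(OCS(=O)(=O)c2ccccc2)c(C)c1`, with 1-(hydroxymethyl)-2-methylpropyl instead, gives 7720 nM and is the strongest of the three in this assay. The step of a 3.4-fold higher number from compound 2 to compound 3 (0.54 log units; beyond the scatter) is a real but modest one.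

Compound 4 `CCn1c(C(=O)N[C@H](CO)CCO)ccc1C(CC)(CC)c1ccc(OCS(=O)(=O)c2ccccc2)c(C)c1` is compound 3 with a single change, (hydroxymethyl in place of hydrogen on a saturated chain carbon bound to an amide-type nitrogen and a saturated chain carbon), which turns 3-hydroxypropyl into 3-hydroxy-1-(hydroxymethyl)propyl. Compound 1 and compound 2 also hold a hydroxymethyl in their groups on that nitrogen, yet they stand apart, with the step of a 5.9-fold lower number from compound 1 to compound 2 (0.77 log units; beyond the scatter) between them. Having a hydroxymethyl there therefore gives no single direction, and no measured compound carries the new group. The expected outcome is a 1.2-fold lower number from compound 3 to compound 4 (0.08 log units; within the scatter), which means no clear step beyond the scatter. For compound 4 the estimated value is 22000 nM, with an expected range from 8000 nM to 55000 nM.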

Compound 4, half-maximal inhibitory concentration: 15900 nM
Compound 4: the middle estimate sits 1.4-fold (0.14 log units) above what was measured, and the stated range covers the measured number.
By their numbers in this assay, from the lowest: compound 2; then compounds 4, 3 and 1 (each within the scatter of the next, the first and the last beyond it).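

In this assay, putting a hydroxymethyl on the saturated chain carbon bound to the amide-type nitrogen and a saturated chain carbon gives no clear shift, with a 1.7-fold lower number from compound 3 to compound 4 (0.22 log units; within the scatter), so adding this group to the 3-hydroxypropyl chain has no effect that can be told from the scatter. The other group on that carbon does count, at least in this pair: compound 2 and compound 4 both hold the hydroxymethyl, and 2-hydroxyethyl in place of isopropyl gives a 2.1-fold higher number from compound 2 to compound 4 (0.31 log units; beyond the scatter), a modest step that is only just beyond the scatter. The open-chain group of compound 4 also stands apart from the 1-(hydroxymethyl)cyclopropyl group, with a 2.9-fold lower number from compound 1 to compound 4 (0.46 log units; beyond the scatter), a separation that compound 3 does not show, though no measurement here explains any of these differences.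

On these data alone, whether an aminomethyl group or a carboxylic acid in place of the hydroxymethyl would move the number beyond the scatter from compound 3 remains open. So does how a longer chain, such as 4-hydroxybutyl on the amide-type nitrogen, or an ethyl or tert-butyl group in place of the isopropyl of compound 2, would compare.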